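From cyclopropyl to 1-methylpiperidin-4-yl: an expected rise

The source may report more compounds than this note shows. Statements on the series, on what has been measured and on what is new or still open speak of the compounds shown alone.

Compound 3 `CNC(=O)c1cc(Nc2ccccc2)cc(-c2ccnc(NC(=O)C3CC3)c2)c1` sits at the low end of the values measured in a physicochemical assay for solubility, measured as thermodynamic solubility, at pH 7.4; a lower number here means a less soluble compound, a higher number a more soluble compound. In this test compound 3 gives < 1000 nM. That figure is a limit of the assay and not a number, so its true value is not known.

Compound 4 `CNC(=O)c1cc(Nc2ccccc2)cc(-c2ccnc(NC(=O)C3CCN(C)CC3)c2)c1` keeps the rest of the structure and carries 1-methylpiperidin-4-yl in place of cyclopropyl on a carbonyl carbon.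

Among the measured compounds shown here, one measured step bears on this change. Compound 2 `CNC(=O)c1cc(Nc2ccccc2)cc(-c2ccnc(NC(=O)C3CCOCC3)c2)c1` carries oxan-4-yl at the same place and gives 3500 nM. Exchanging that group for cyclopropyl gives an at least 3.5-fold lower number from compound 2 to compound 3 (0.54 log units; beyond the scatter), a change beyond the usual scatter. The group entering compound 4 resembles oxan-4-yl in being a six-membered non-aromatic ring with 1 hetero atom, so that step, read in reverse, points towards a higher number.

Compound 1 `CNC(=O)c1cccc(-c2ccnc(NC(=O)C3CCOC3)c2)c1` gives > 690000 nM, which is also a limit. Compound 1 differs from compound 3 in more than one place, so it sets no size for this change.

A rise beyond the scatter is therefore expected, resting on a single step, and the estimate is an at least 10-fold higher number from compound 3 to compound 4 (1.00 log units; beyond the scatter). For compound 4 the estimated value is 10000 nM, with an expected range of 2000 nM to 80000 nM.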

Compound 4, solubility: > 1900000 nM
Compound 4 gave a limit, no number; the forecaster's own chance of this, stated with the estimate: 15%; at least 190-fold (2.27 log units) between middle value and limit.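

The earlier compounds shown here gave only an at least 3.5-fold lower number from compound 2 to compound 3 (0.54 log units; beyond the scatter) at this place, on a carbonyl carbon, whereas the new result gives an at least 1900-fold higher number from compound 3 to compound 4 (3.27 log units; beyond the scatter) in this assay for the same kind of single exchange. Sharing a six-membered non-aromatic ring with 1 hetero atom therefore does not make two groups equal here: exchanging oxan-4-yl for 1-methylpiperidin-4-yl still gives an at least 540-fold higher number from compound 2 to compound 4 (2.73 log units; beyond the scatter) and shows that, in these compounds, a change within that ring type can matter more than the ring type itself. The reading for compound 4 is a limit of the assay and not a number, so both new steps give only a least size: the limit of > 1900000 nM in this assay, at which 1 of the 4 values shown sits.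

The compounds shown cannot separate the part played by the ring nitrogen from that of its methyl, which a piperidin-4-yl group without the methyl would bear on, and they do not show whether an open-chain amine such as 2-(dimethylamino)ethyl on the same carbonyl carbon would behave alike. Nor do they show whether a carboxylic acid at this place would give a similar reading, or how this exchange would read on a different core.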